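This account rests on a few compounds, and the source may have more. Where it says the series, first, only, none or still open, it means among the compounds named here.

Compound 1 `C=CCCN1CCC(CCCn2c(COc3ccccc3)nc3c(OCCCN4CCCCC4)cccc32)CC1` gives 0.707 nM in an in vitro assay on AV12 cells for binding affinity to Neuropeptide Y receptor type 1 (Homo sapiens) (a lower number here means a stronger inhibitor, a higher number a weaker inhibitor), and stands at the highest number of the three measured. Compound 2 `c1ccc(OCc2nc3c(OCCCN4CCCCC4)cccc3n2CCCC2CCN(CCCN3CCCCC3)CC2)cc1` gives 0.106 nM in this assay, and compound 3 `c1ccc(CCCN2CCC(CCCn3c(COc4ccccc4)nc4c(OCCCN5CCCCC5)cccc43)CC2)cc1` gives 0.361 nM. Both measured steps away from compound 1 replace the same vinyl: a 6.7-fold lower number from compound 1 to compound 2 (0.82 log units; beyond the scatter) and a 2.0-fold lower number from compound 1 to compound 3 (0.29 log units; within the scatter). Between those two products, a 3.4-fold higher number from compound 2 to compound 3 (0.53 log units; beyond the scatter).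

Compound 4 `CC(C)CCN1CCC(CCCn2c(COc3ccccc3)nc3c(OCCCN4CCCCC4)cccc32)CC1` differs from compound 1 by isopropyl in place of vinyl on a saturated chain carbon, two bonds along the chain from an amine nitrogen in a ring. The two steps from compound 1 are the ones that bear on this change; the one that brings in a piperidin-1-yl ring lowers the number beyond the scatter, while the one that brings in benzyl stays within it. Isopropyl enters with no ring and with no nitrogen, so the closer comparison is the benzyl step, not the piperidin-1-yl step. For compound 4 the expected step is therefore small, if anything toward a lower number, and within the scatter: a 1.4-fold lower number from compound 1 to compound 4 (0.15 log units; within the scatter). Compound 4 is expected to give 0.5 nM, between 0.2 nM and 1.4 nM.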

Compound 4, inhibition constant: 0.29 nM
The estimate for compound 4 lay 1.7-fold (0.24 log units) above the measured number; the measured number falls inside the stated range.
By their numbers in this assay, from the lowest: compound 2; then compounds 4, 3 and 1 (each within the scatter of the next, the first and the last beyond it).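

Removing the double bond and adding one carbon at this chain position gives a 2.4-fold lower number from compound 1 to compound 4 (0.39 log units; beyond the scatter) in this assay and so moves the number beyond the scatter, which the earlier vinyl-to-benzyl step did not do. A small all-carbon group with no ring holds up as well as benzyl, with a 1.2-fold lower number from compound 3 to compound 4 (0.10 log units; within the scatter) and so no ring is needed here to reach this level. The (piperidin-1-yl)methyl group of compound 2 stays apart, with a 2.7-fold higher number from compound 2 to compound 4 (0.44 log units; beyond the scatter) and so the advantage of compound 2 is not matched by either carbon-only group.

Going by these compounds, whether that advantage follows the amine nitrogen or the ring stays open, and a cyclohexylmethyl or a dimethylaminomethyl group in the same place would separate the two. No measurement at hand gives a reason for these steps.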